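This account rests on a few compounds, and the source may have more. Where it says the series, first, only, none or still open, it means among the compounds named here.

Going by the values given here, in an in vitro functional assay on cells for agonist activity at Bombesin receptor subtype-3 (Homo sapiens), read by luminescence and calcium flux (a lower number here means that less compound is needed, a higher number that more compound is needed for the effect), compound 2 `CC(C)(C)c1cnc(CCc2ccc(-c3ccccc3C(=O)O)cc2)[nH]1` gives 4330 nM, the higher of the two numbers measured so far; compound 1 `Cc1ccccc1Cc1cnc(CCc2ccc(-c3ccccc3C(=O)O)cc2)[nH]1` gives 127 nM. Compound 3 `COc1ccccc1Cc1cnc(CCc2ccc(-c3ccccc3C(=O)O)cc2)[nH]1` has not yet been measured in this assay. From compound 2 to compound 3 the change is 2-methoxybenzyl in place of tert-butyl on an aromatic carbon. Among the compounds with values here, the single measured step bears directly on it: a 34-fold higher number from compound 1 to compound 2 (1.53 log units; beyond the scatter), and the step to compound 3 runs that change in reverse, with 2-methoxybenzyl entering where compound 1 carries 2-methylbenzyl. A large move toward a lower number is therefore expected in this assay, a 29-fold lower number from compound 2 to compound 3 (1.46 log units; beyond the scatter). Compound 3 is estimated at 150 nM, with a range from 40 nM to 600 nM.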

Compound 3, half-maximal effective concentration: 1720 nM
Compound 3: the middle estimate sits 11-fold (1.06 log units) below what was measured, and the stated range ends below it.
By their numbers in this assay, from the lowest: compound 1; then compound 3; then compound 2.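

Replacing tert-butyl with 2-methoxybenzyl gives a 2.5-fold lower number from compound 2 to compound 3 (0.40 log units; beyond the scatter) in this assay and so recovers only a small part of the gap to compound 1. The small group on the benzyl ring also counts at this place, as methoxy in place of methyl gives a 14-fold higher number from compound 1 to compound 3 (1.13 log units; beyond the scatter) and leaves compound 3 well short of compound 1. Nothing available explains this difference.

From the compounds shown here alone, it remains open how an unsubstituted benzyl or a 2-chlorobenzyl would compare with compound 1. The compounds shown also leave open whether the methyl of compound 1 could be replaced by an ethyl without a similar loss.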